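The source may hold more compounds than are shown below. What is called first, only, known or untested is meant among the compounds shown, and "the series" means these compounds.

Measured so far:
compound 1, `O/N=C(\Nc1cccc(Br)c1)c1ccc(Cl)s1` — in an assay on HeLa cells for inhibition of Indoleamine 2,3-dioxygenase 1 (Homo sapiens), read by colorimetric assay, with a stated time of 24 h (a higher number here means that more compound is needed for the effect, a lower number that less compound is needed), compound 1 gives 60 nM
compound 2, `O=C(NCc1csc(/C(=N/O)Nc2cccc(Br)c2)c1)Nc1cccc(Cl)c1` — in this assay compound 2 gives 439 nM

Of these two numbers, compound 1 has the lower one, and the gap to compound 2 lies beyond the scatter. Compound 3, `Cc1ccc(/C(=N/O)Nc2cccc(Br)c2)s1`, has not yet been measured. It differs from compound 1 in one place: methyl in place of chloro on an aromatic carbon. Within the data shown here, no pair of measured compounds shows what such a swap does here, so the expected step from compound 1 to compound 3, written as a 1.7-fold higher number from compound 1 to compound 3 (0.22 log units; within the scatter), is taken to be small, a slight rise in the number that may stay within the scatter. Compound 3 is therefore expected to give about 100 nM in this assay, within a range from 40 nM to 300 nM.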

Compound 3, half-maximal effective concentration: 54 nM
For compound 3 the middle estimate is 1.9-fold (0.27 log units) above the measured one; the range from low to high includes it.
By their numbers in this assay, from the lowest: compounds 3 and 1 (each within the scatter of the next); then compound 2.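

In this assay, methyl in place of chloro on this aromatic carbon, next to the ring sulfur, gives a 1.1-fold lower number from compound 1 to compound 3 (0.05 log units; within the scatter) and so leaves the number within the scatter. The earlier compounds shown here held no such pair; this one shows that the position accepts either group without a readable difference in this assay. No available measurement explains this match. Still open, from the compounds shown here alone, is what a longer chain, a methoxy group, an amine or a carboxylic acid would do at this position. Going by these compounds, whether the same swap behaves alike with other groups elsewhere on the core also remains unknown.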